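Series notes: chloro on the phenyl triazole, compound 4

A few compounds are considered here, and "the series" means these few. Any claim that something is new, unique, unknown or untested is made for them only; others in the source may bear on it.

Measured so far, all in the same cell assay:
compound 1, `C=C1C[C@]23C[C@@]1(O)CC[C@H]2c1cc(Br)c(O)c(C)c1[C@@H]3Cn1cc(-c2ccc(Cl)cc2)nn1`: 10200 nM
compound 2, `C=C1C[C@]23C[C@@]1(O)CC[C@H]2c1ccc(O)c(C)c1[C@@H]3Cn1cc(-c2ccccn2)nn1`: > 20000 nM (a limit of the assay)
compound 3, `C=C1C[C@]23C[C@@]1(O)CC[C@H]2c1ccc(O)c(C)c1[C@@H]3Cn1cc(-c2ccccc2)nn1`: > 20000 nM (a limit of the assay)

In a functional assay on MCF7 cells (Homo sapiens) for cytotoxicity, read by MTT assay, with a stated time of 4 days (a lower number here means a stronger inhibitor, a higher number a weaker inhibitor), compound 1 gives 10200 nM. Compound 2 reaches only a limit of this assay, > 20000 nM. Compound 3 likewise reaches only a limit of this assay, > 20000 nM. Compound 3 therefore stands at the limit of > 20000 nM in this assay, at which 2 of the 3 values shown sit, and the step that the two limits leave unreadable from compound 2 to compound 3 cannot be read in size.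

The next compound, compound 4, is `C=C1C[C@]23C[C@@]1(O)CC[C@H]2c1ccc(O)c(C)c1[C@@H]3Cn1cc(-c2ccc(Cl)cc2)nn1`. The change from compound 3 is chloro in place of hydrogen on an aromatic carbon. Among the compounds with values here, no measured step covers this change, so nothing of the measured steps can be carried over to it. Compound 1 carries the same 4-chlorophenyl group as compound 4 on a core that additionally bears bromo, and compound 1 gives 10200 nM, a number inside the measured range. Compound 3 sits at a limit of this assay. Within the data shown here, no single step joins compound 1 and compound 4.

Compound 4 is expected to lie near the limit, estimated at 15000 nM with a range from 7000 nM to 40000 nM. The step of an at least 1.3-fold lower number from compound 3 to compound 4 (0.12 log units; that floor lies within the scatter) is expected to be small or unreadable.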

Compound 4, half-maximal inhibitory concentration: > 20000 nM
Compound 4: a limit, no number; the forecaster's own chance of this, stated with the estimate: 50%; middle value at least 1.3-fold (0.12 log units) away from the limit.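

In this assay compound 4 stays at a limit of the assay, > 20000 nM, so the change from phenyl to 4-chlorophenyl does not by itself give a readable value. The steps to compound 4 from compound 2 and from compound 3 cannot be read, and most of the series shown now sits at a single limit: the limit of > 20000 nM in this assay, at which 3 of the 4 values shown sit. Within the data shown here, the one readable step is hydrogen in place of bromo on an aromatic carbon, an at least 1.9-fold higher number from compound 1 to compound 4 (0.29 log units; that floor lies within the scatter), and this pair isolates the bromo for the first time, although the printed floor does not show that the bromo matters and the true gap may be larger.

As far as these compounds go, the size of the bromo contribution stays open, as does whether bromo on the core of compound 3, without any chloro, would bring a value inside the measured range. Also open, from the compounds shown here alone, is whether an amine or a carboxylic acid in place of chloro on the 4-chlorophenyl group would move the series off the limit.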